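A few compounds are considered here, and "the series" means these few. Any claim that something is new, unique, unknown or untested is made for them only; others in the source may bear on it.

Measured in a functional assay on SW982 cells (Homo sapiens) for inhibition, read by MTT assay, with a stated time of 72 h; on this read-out higher numbers stand for weaker inhibition and lower numbers for stronger inhibition:
- Compound 1 `COc1cc(OC)c(-c2cc(=O)c3cc(Cl)ccc3o2)cc1OC`: > 150000 nM, a limit of the assay and not a number
- Compound 2 `COc1cc(OC)c(OC)cc1/C=C/C(=O)c1ccc(O)cc1O`: 32400 nM

For the measured compounds named here, compound 2 gives the only actual number in this assay, 32400 nM. The result for compound 1 is a limit, so the two cannot be separated by a precise gap.

The next compound, compound 3 `COc1cc(OC)c(OC)cc1/C=C/C(=O)c1ccc(O)cc1`, has yet to be measured. It differs from compound 2 by one small change, hydrogen in place of hydroxy on an aromatic carbon, which turns 2,4-dihydroxyphenyl into 4-hydroxyphenyl.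

Going by the values given here, no measured pair here shows what this change does, so the expectation is loose. With compound 2 at 32400 nM as the only anchor, a modest step toward weaker inhibition is expected, and it may not rise beyond the usual scatter of this assay. The expected change is a 1.4-fold higher number from compound 2 to compound 3 (0.14 log units; within the scatter). For compound 3, the estimated value is 45000 nM, with an expected range of 15000 nM to 130000 nM.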

Compound 3, half-maximal inhibitory concentration: 155000 nM
Compound 3: middle estimate off by 3.4-fold (0.54 log units), on the low side, and the stated range ends below it.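

In this assay, for the compounds shown here, the earlier compounds gave one number and one limit, and they differ in more than one place, so they could not show what any single group contributes. Compounds 2 and 3 differ in one place, and they isolate the hydroxy on an aromatic carbon, ortho to a large group and meta to the other hydroxy group: replacing it with hydrogen, which turns 2,4-dihydroxyphenyl into 4-hydroxyphenyl, gives a 4.8-fold higher number from compound 2 to compound 3 (0.68 log units; beyond the scatter), a clear move toward weaker inhibition, so in this pair the hydroxy at this position matters for the effect on these cells. The number for compound 3 also lies close to the only limit shown, which belongs to compound 1 and is a limit and not a number: the limit of > 150000 nM in this assay, at which 1 of the 3 values shown sits.

As far as these compounds go, this single pair compares only hydroxy and hydrogen at this position, so it remains open how an amine or a fluorine atom there would behave. Also open, from the compounds shown here alone, are what the remaining hydroxy group contributes and whether the same change would have a similar effect on the core of compound 1.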